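Aryl ether tail swap on a pyrrolidine acetic acid

The compounds below may be only part of what the source reports. "The series", "measured", "known", "first", "only" and "open" are said of these compounds alone.

Of the compounds shown here, two sharing one core have been measured so far. Compound 1 `O=C(O)C[C@@H]1CCCN1c1ccc(Oc2ccc(Cl)cc2Cl)cc1` gives 360 nM in a functional assay on cells for agonist activity at Free fatty acid receptor 1 (Homo sapiens), read by FLIPR and calcium flux, with a stated time of 100 s (on this read-out lower numbers stand for an effect already at smaller amounts and higher numbers for an effect only at larger amounts of compound), and stands as the lower of the two numbers. Compound 2 `O=C(O)C[C@@H]1CCCN1c1ccc(Oc2ccccc2-c2ccccc2)cc1` gives 3500 nM in this assay, a gap from compound 1 that lies beyond the usual scatter. For the measured compounds named here, no single-point step between measured compounds is available, so the next change can only be judged against the value of compound 1.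

Compound 3 `COc1ccc(Oc2ccc(N3CCC[C@H]3CC(=O)O)cc2)cc1` differs from compound 1 by 4-methoxyphenyl in place of 2,4-dichlorophenyl on an oxygen on an aromatic ring. With only the number of compound 1 360 nM to rest on, a moderate step upward in this assay is expected, meaning an effect only at somewhat larger amounts, though a result within the scatter of compound 1 cannot be excluded. For compound 3 the expected step is a 3.1-fold higher number from compound 1 to compound 3 (0.49 log units; beyond the scatter). Compound 3 is thus estimated at 1100 nM, with a range from 300 nM to 4500 nM.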

Compound 3, half-maximal effective concentration: 520 nM
The estimate for compound 3 lay 2.1-fold (0.33 log units) above the measured number; measured number inside the range.
By their numbers in this assay, from the lowest: compounds 1 and 3 (each within the scatter of the next); then compound 2.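

In this assay, for the compounds shown here, 4-methoxyphenyl in place of 2,4-dichlorophenyl on an oxygen on an aromatic ring gives a 1.4-fold higher number from compound 1 to compound 3 (0.16 log units; within the scatter) in the only single-point step yet available. The change therefore separates compound 3 from compound 1 by no more than the scatter. At this position, then, a ring with no chlorine and with one hydrogen-bond acceptor, in place of one with two chlorines and none, reads alike in this assay, and nothing measured here accounts for that result.

On these data alone, whether the two chlorines and the methoxy group each matter on their own remains open. A plain phenyl or a 4-chlorophenyl on that oxygen would be needed to separate them, and the effect of a 4-cyanophenyl there is equally unknown.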